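Swapping Benzyl for Cyclohexyl on the Amide Nitrogen

The compounds below may be only part of what the source reports. "The series", "measured", "known", "first", "only" and "open" are said of these compounds alone.

In an ADME assay on MRC5 cells (Homo sapiens) for inhibition, with a stated time of 72 h (on this read-out higher numbers stand for an effect only at larger amounts of compound and lower numbers for an effect already at smaller amounts), compound 2 `COc1cccc(OC)c1C(=O)Nc1c[nH]nc1C(=O)NCc1ccccc1` gives 50000 nM, the highest of the three numbers recorded. Compound 1 `CO[C@H]1CC[C@H](NC(=O)c2n[nH]cc2NC(=O)c2ccccc2)CC1` gives 800 nM, and compound 3 `CO[C@H]1CC[C@H](NC(=O)c2n[nH]cc2NC(=O)c2ccc(N3CCN(C)CC3)cc2)CC1` gives 20000 nM. Compound 4 `COc1cccc(OC)c1C(=O)Nc1c[nH]nc1C(=O)NC1CCCCC1` differs from compound 2 by cyclohexyl in place of benzyl on an amide-type nitrogen. Among the compounds with values here, the only measured step, a 25-fold higher number from compound 1 to compound 3 (1.40 log units; beyond the scatter), concerns a different place on the shared core and does not bear on this change; no measured pair shows the exchange of benzyl for cyclohexyl on the amide-type nitrogen. With nothing to point in either direction, no step beyond the scatter is expected for compound 4, so no change at the digits printed from compound 2 to compound 4 (within the scatter) is the estimated outcome. Compound 4 is therefore expected to give about 50000 nM in this assay, somewhere between 15000 nM and 150000 nM.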

Compound 4, half-maximal effective concentration: 35000 nM
Estimate against measurement, compound 4: 1.4-fold (0.15 log units) above; measured number inside the range.
By their numbers in this assay, from the lowest: compound 1; then compounds 3, 4 and 2 (each within the scatter of the next, the first and the last beyond it).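

In this assay, the step at this amide-type nitrogen is a 1.4-fold lower number from compound 2 to compound 4 (0.15 log units; within the scatter), so on this core the number does not separate benzyl from cyclohexyl. Within the data shown here, this is the first measured step at this place, and it shows that an aromatic ring of carbon can give way to a non-aromatic one, with one heavy atom fewer, without a step beyond the scatter. Nothing measured here offers a reason for this result.

On these data alone, whether an amine, a carboxylic acid or a longer chain on this nitrogen would shift the number remains open. So does whether the same exchange would read alike with a different group on the other amide.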